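Removing the ethyl group from compound 1

The source may report more compounds than this note shows. Statements on the series, on what has been measured and on what is new or still open speak of the compounds shown alone.

In a functional assay for inhibition, with Homo sapiens as the target (on this read-out lower numbers stand for stronger inhibition and higher numbers for weaker inhibition), compound 1 `CCC1(O)CS(=O)(=O)c2cc(C(=O)N=C(N)N)c(C)cc21` gives 77 nM. Compound 2 `C=C1c2cc(C)c(C(=O)N=C(N)N)cc2S(=O)(=O)C1(C)C` gives 114 nM, within the scatter of compound 1. Compound 3 `Cc1cc2c(cc1C(=O)N=C(N)N)S(=O)(=O)C(C)(C)C2=O` gives 354 nM, a higher number beyond the scatter from compound 1.

The next analogue, compound 4 `Cc1cc2c(cc1C(=O)N=C(N)N)S(=O)(=O)CC2O`, differs from compound 1 by hydrogen in place of ethyl on a saturated ring carbon, with hydrogen in place of ethyl on a saturated ring carbon. Within the data shown here, no measured pair isolates this change, so the size of the step remains uncertain. The measured values reach only as far as compound 3 at 354 nM, so a moderate move toward weaker inhibition in this assay is expected. The estimated change is a 2.3-fold higher number from compound 1 to compound 4 (0.37 log units; beyond the scatter). For compound 4 the estimated value is 180 nM, with an expected range of 60 nM to 540 nM.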

Compound 4, half-maximal inhibitory concentration: 1050 nM
Compound 4: the middle estimate sits 5.8-fold (0.77 log units) below what was measured; measured number outside the range, above it.
By their numbers in this assay, from the lowest: compounds 1 and 2 (each within the scatter of the next); then compound 3; then compound 4.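

In this assay, hydrogen in place of ethyl on a saturated ring carbon gives a 14-fold higher number from compound 1 to compound 4 (1.13 log units; beyond the scatter), a large move toward weaker inhibition. Among these compounds, compound 2 and compound 3 differ from compound 1 in more than one place, so this step is the first to isolate this position, and it shows that the ethyl group matters here. Nothing on hand accounts for the size of this step.

Going by these compounds, whether a methyl group would retain part of the inhibition seen with ethyl remains open. So does the outcome with a longer chain such as propyl, or with an amine, at this carbon.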